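This account rests on a few compounds, and the source may have more. Where it says the series, first, only, none or still open, it means among the compounds named here.

Measured so far:
compound 1 `O=C(Nc1ccc2nc(NC(=O)C3CCCCC3)sc2c1)c1ccc(Br)cc1` — in a functional assay on WI-38 VA13 cells (Homo sapiens) for cytotoxicity (on this read-out higher numbers stand for an effect only at larger amounts of compound and lower numbers for an effect already at smaller amounts), compound 1 gives only the limit > 4 ug/mL.
compound 2 `CC(=O)Nc1nc2ccc(NC(=O)c3c(Cl)cccc3Cl)cc2s1` — compound 2 gives 0.6 ug/mL.
compound 3 `CCOC(=O)Nc1nc2ccc(NC(=O)c3c(Cl)cccc3Cl)cc2s1` — compound 3 gives 0.0026 ug/mL.

Compound 3 stands lowest of the two numbers; its nearest neighbour is compound 2, and the step of a 230-fold lower number from compound 2 to compound 3 (2.36 log units; beyond the scatter) is large. Compound 1 contributes only a limit (the limit of > 4 ug/mL in this assay, at which 1 of the 3 values shown sits).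

Compound 4 `O=C(NCc1ccccc1)Nc1nc2ccc(NC(=O)c3c(Cl)cccc3Cl)cc2s1` differs from compound 3 by benzylamino in place of ethoxy on a carbonyl carbon, ethoxycarbonyl to benzylcarbamoyl. For the measured compounds named here, the only measured step at this carbonyl carbon is a 230-fold lower number from compound 2 to compound 3 (2.36 log units; beyond the scatter); it shows the position is sensitive, but benzylamino was not tested, so direction is uncertain. A moderate step upward is expected, a 7.7-fold higher number from compound 3 to compound 4 (0.89 log units; beyond the scatter), giving an estimated 0.02 ug/mL for compound 4, within 0.002 ug/mL to 0.3 ug/mL.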

Compound 4, half-maximal effective concentration: 0.15 ug/mL
Compound 4: the middle estimate sits 7.5-fold (0.88 log units) below what was measured; low and high end bracket the measured number.
By their numbers in this assay, from the lowest: compound 3; then compound 4; then compound 2. At a limit, above all of these: compound 1.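

Benzylamino in place of ethoxy on the carbonyl carbon gives a 58-fold higher number from compound 3 to compound 4 (1.76 log units; beyond the scatter), so the very low number of compound 3 does not carry over to this larger group with a ring. Against methyl, benzylamino gives a 4.0-fold lower number from compound 2 to compound 4 (0.60 log units; beyond the scatter), so the order at this place runs ethoxy, benzylamino, methyl, with every step beyond the scatter. No measured property available here accounts for these steps.

Benzylamino brings in a nitrogen and a ring together, and which of the two goes with the higher number stays open. Benzyloxy and ethylamino on this carbonyl carbon would separate them.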